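Fluoro for Methyl on a Fused Aromatic Ester Core

The source may hold more compounds than are shown below. What is called first, only, known or untested is meant among the compounds shown, and "the series" means these compounds.

Compound 1, `C=C(C)[C@@H](OC(=O)c1ccc(F)c2ccccc12)C(N)=O`: a limit in a functional assay on CHO cells (Cricetulus griseus) for inhibition, read by MTT assay, with a stated time of 96 h (on this read-out lower numbers stand for stronger inhibition and higher numbers for weaker inhibition), > 100000 nM.
Compound 2, `Cc1ccc(C(=O)O[C@H](C(N)=O)C2(C)CO2)c2ccccc12`: 6000 nM in this assay.
Compound 3, `C=C(C)[C@@H](OC(=O)c1ccc(C)c2ccccc12)C(N)=O`: a limit in this assay, > 100000 nM.

Among the measured compounds shown here, compound 2 gives the only number in this assay; the other two values are limits. The step that the two limits leave unreadable from compound 3 to compound 1 cannot be read because of the limit of > 100000 nM in this assay, at which 2 of the 3 values shown sit. The change is fluoro in place of methyl on an aromatic carbon. The difference between the core of compound 2 and the core of compound 3 is not broken down here.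

Compound 4, `CC1([C@H](OC(=O)c2ccc(F)c3ccccc23)C(N)=O)CO1`, is not yet measured. It differs from compound 2 by fluoro in place of methyl on an aromatic carbon, the same change as that from compound 3 to compound 1, at a place described in the same words. Since that measured step is unreadable, the expectation for compound 4 rests on compound 2 alone, with a step of no change at the digits printed from compound 2 to compound 4 (within the scatter) expected. Compound 4 is estimated at 6000 nM, between 1500 nM and 30000 nM.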

Compound 4, half-maximal inhibitory concentration: 7000 nM
Compound 4: middle estimate off by 1.2-fold (0.07 log units), on the low side; measured number inside the range.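

In this assay, fluoro in place of methyl on an aromatic carbon of the core of compound 2 gives a 1.2-fold higher number from compound 2 to compound 4 (0.07 log units; within the scatter), so on this core the two groups cannot be told apart. The same change on the other core, from compound 3 to compound 1, cannot be read, because both of its values are limits: the limit of > 100000 nM in this assay, at which 2 of the 4 values shown sit. The series therefore offers one readable instance of this change, and it does not show whether the change carries from one core to the other.

The compounds shown leave open how chloro, methoxy, nitrile or an amine would fare on that same aromatic carbon. They also leave open what a carboxylic acid would do in place of the amide on the core of compound 2.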